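Bromo to pentafluoroethyl on compound 3

The source may hold more compounds than are shown below. What is called first, only, known or untested is meant among the compounds shown, and "the series" means these compounds.

Among the measured compounds shown here, compound 3 `O=C(Nc1ccc(Br)cc1)c1csc(Cc2c(Cl)cccc2Cl)n1` is the one member of the series with a number in an assay on CHO cells, read by calcium flux; a higher number here means a weaker inhibitor, a lower number a stronger inhibitor: there compound 3 gives 400 nM. Compound 1 `O=C(Nc1ccccc1)c1csc(Cc2c(Cl)cccc2Cl)n1` returns only a limit of the assay in this assay, compound 1 giving > 4000 nM. Compound 2 `COc1ccc(NC(=O)c2csc(Cc3c(Cl)cccc3Cl)n2)cc1` likewise stops at a limit in this assay, compound 2 giving > 4000 nM. The step that the two limits leave unreadable from compound 1 to compound 2 cannot be read between two limits. The steps of an at least 10-fold lower number from compound 1 to compound 3 (1.00 log units; beyond the scatter) and an at least 10-fold lower number from compound 2 to compound 3 (1.00 log units; beyond the scatter) show that bromo on the aromatic carbon carries the gain, and the limit of > 4000 nM in this assay, at which 2 of the 3 values shown sit, sets how much of that gain can be read. Compound 4 `O=C(Nc1ccc(C(F)(F)C(F)(F)F)cc1)c1csc(Cc2c(Cl)cccc2Cl)n1` differs from compound 3 by 1,1,2,2,2-pentafluoroethyl in place of bromo on an aromatic carbon. For the measured compounds named here, no measured step exchanges bromo for another group on that carbon, so only the bromo steps into compound 3 speak, and they show that the carbon accepts a substituent. The expected step is no change at the digits printed from compound 3 to compound 4 (within the scatter), within the usual scatter. Compound 4 is estimated at 400 nM in this assay, between 130 nM and 1300 nM.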

Compound 4, half-maximal inhibitory concentration: 290 nM
The estimate for compound 4 lay 1.4-fold (0.14 log units) above the measured number; low and high end bracket the measured number.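

In this assay, the aromatic carbon para to a large group now holds a second substituent: 1,1,2,2,2-pentafluoroethyl, with 7 heavy atoms, replaces bromo, with 1, and the result is a 1.4-fold lower number from compound 3 to compound 4 (0.14 log units; within the scatter), so the two groups cannot be told apart here. The gain over methoxy and hydrogen is therefore not unique to bromo, with an at least 13-fold lower number from compound 2 to compound 4 (1.13 log units; beyond the scatter) and an at least 13-fold lower number from compound 1 to compound 4 (1.13 log units; beyond the scatter). Those two steps start from a limit of the assay, so their full size stays unread: the limit of > 4000 nM in this assay, at which 2 of the 4 values shown sit.

From the compounds shown here alone, whether the gain would survive with an amine, a carboxylic acid or a plain ethyl chain on that carbon stays open. Going by these compounds, how much longer a perfluorinated chain could grow there is equally open.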